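Para Substituent Swap on a Bis(trifluoromethyl)benzenesulfonamide Series

The source may report more compounds than this note shows. Statements on the series, on what has been measured and on what is new or still open speak of the compounds shown alone.

The account concerns three compounds built on the same sulfonamide core. Compound 1 `O=S(=O)(NCCNCc1cccc2ccccc12)c1cc(C(F)(F)F)cc(C(F)(F)F)c1` carries a naphthylmethyl group on the amine, and in a functional assay on MIA PaCa-2 cells (Homo sapiens) for inhibition, read by MTT assay, with a stated time of 72 h (a higher number here means a weaker inhibitor of growth, a lower number a stronger inhibitor of growth), compound 1 gives 26000 nM. Compound 2 `O=S(=O)(NCCNCc1ccc(-c2ccccc2)cc1)c1cc(C(F)(F)F)cc(C(F)(F)F)c1` carries a biphenylmethyl group instead, and in this assay compound 2 gives 2700 nM. For the measured compounds named here, of the two numbers known so far, compound 2 has the lower one, and the gap to compound 1 lies beyond the usual scatter of this kind of measurement, so compound 2 is the stronger growth inhibitor of the pair.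

Compound 3 `CC(C)(C)c1ccc(CNCCNS(=O)(=O)c2cc(C(F)(F)F)cc(C(F)(F)F)c2)cc1` has not yet been measured. It differs from compound 2 in one place: tert-butyl in place of phenyl on an aromatic carbon. Going by the values given here, no pair of measured compounds shows what such a change does in this assay, so the expectation rests on the two values alone. Because compound 2 gives 2700 nM, the step is expected to be small, a 1.7-fold higher number from compound 2 to compound 3 (0.22 log units; within the scatter), either within the scatter or tending toward a weaker result. Compound 3 is therefore estimated at 4500 nM, with a range from 1500 nM to 14000 nM.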

Compound 3, concentration for 50% growth inhibition: 15000 nM
For compound 3 the middle estimate is 3.3-fold (0.52 log units) below the measured one; measured number outside the range, above it.
By their numbers in this assay, from the lowest: compound 2; then compounds 3 and 1 (each within the scatter of the next).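

For the compounds shown here, the phenyl on the aromatic carbon para to a large group proves to matter: putting tert-butyl in its place gives a 5.6-fold higher number from compound 2 to compound 3 (0.74 log units; beyond the scatter) in this assay and is the first measured change at this position. The group that enters has no ring and fewer heavy atoms, and among these three compounds only compound 2, with its phenyl, stands apart, since the other measured step, a 1.7-fold lower number from compound 1 to compound 3 (0.24 log units; within the scatter) for 4-(tert-butyl)phenyl in place of naphthalen-1-yl, shows no separation between compound 1 and compound 3. Nothing available explains the loss seen on leaving phenyl for tert-butyl.

The compounds shown leave open whether the ring itself or simply a group of that size is what compound 2 needs at this position, a question that a cyclohexyl group or a pyridyl ring in place of the phenyl would address. They also leave open how a smaller methyl group, a methoxy group or a phenoxy group would fare at the same carbon, so a single step defines this position for now.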